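Amino acid tail variation on the shared core

This account rests on a few compounds, and the source may have more. Where it says the series, first, only, none or still open, it means among the compounds named here.

Values in a functional assay on the whole organism (Tail, strain ICR) with Mus musculus as the target, in the tail flick test, with a stated time of 30 min, at a dose of 25 umol/kg by the oral route; a higher number here means a stronger effect of the compound at the dose given, a lower number a weaker effect:
Compound 1 `O=C(O)[C@@H]1CCCN1C(=O)CN(c1nc(Cl)nc2[nH]cnc12)C1CC1`: 31.5%
Compound 2 `O=C(CN(c1nc(Cl)nc2[nH]cnc12)C1CC1)N[C@@H](CO)C(=O)O`: 38.7%
Compound 3 `O=C(O)CC[C@H](NC(=O)CN(c1nc(Cl)nc2[nH]cnc12)C1CC1)C(=O)O`: 26.8%

Compound 3 stands lowest of the three numbers in this assay, though only the gap to compound 2 lies beyond the scatter; compound 1 sits within the scatter of it. The two measured steps are a number 7.2 percentage points higher from compound 1 to compound 2 (within the scatter) and a number 11.9 percentage points lower from compound 2 to compound 3 (beyond the scatter).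

Compound 4 `C[C@@H](O)[C@H](NC(=O)CN(c1nc(Cl)nc2[nH]cnc12)C1CC1)C(=O)O` is the next one for this assay. Its change from compound 3 is 1-hydroxyethyl in place of 2-carboxyethyl on a saturated chain carbon bound to an amide-type nitrogen and a carbonyl carbon. The group that enters carries a hydroxy, as compound 2 does, while the group that leaves carries the carboxy that distinguishes compound 3 from compound 2. Among the compounds with values here, the bearing step is therefore the one from compound 2 to compound 3, a modest drop beyond the scatter; compound 4 largely undoes that change, with an added methyl on the hydroxy-bearing carbon for which no measured step gives a guide. A return toward the level of compound 2 is expected, and the step is expected to be upward, of about the size seen from compound 2 to compound 3 but reversed.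

Compound 4 is estimated at 37%, with a range of 27% to 47%. The expected step is a number 10.2 percentage points higher from compound 3 to compound 4 (beyond the scatter).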

Compound 4, a percentage reported as activity, at one dose (the size of the read-out at that dose, not a potency): 18.6%
Compound 4: middle estimate off by 18.4 percentage points, on the high side, and the stated range ends above it.
By their numbers in this assay, from the lowest: compounds 4, 3, 1 and 2 (each within the scatter of the next, the first and the last beyond it).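

In this assay, a hydroxy on the side chain does not by itself hold the read-out up at this position: with 1-hydroxyethyl in place of 2-carboxyethyl on the saturated chain carbon bound to an amide-type nitrogen and a carbonyl carbon, the result is a number 8.2 percentage points lower from compound 3 to compound 4 (within the scatter), so this exchange shows no separation from the carboxy-bearing chain. The more informative change is a single methyl in place of hydrogen on the hydroxy-bearing chain carbon, which gives a number 20.1 percentage points lower from compound 2 to compound 4 (beyond the scatter), showing that the read-out at this dose responds to a small addition to the side chain and that hydroxy-bearing tails cannot be treated as one group. The same holds against the ring-containing tail, where exchanging it for the hydroxy-bearing tail gives a number 12.9 percentage points lower from compound 1 to compound 4 (beyond the scatter).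

No measurement at hand offers an explanation for these steps. As far as these compounds go, it remains open what a plain alkyl chain such as isopropyl, an amine such as aminobutyl, or a longer hydroxyalkyl chain would give on this chain carbon in this assay.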